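The source may report more compounds than this note shows. Statements on the series, on what has been measured and on what is new or still open speak of the compounds shown alone.

Measured so far in an ADME assay on HFF cells (Homo sapiens) for cytotoxicity, read by MTT assay, with a stated time of 72 h; on this read-out higher numbers stand for weaker inhibition and lower numbers for stronger inhibition:
compound 1 `Cc1ccc(-c2cn(C/C=C3\OC(=O)C(OCc4ccccc4)=C3OCc3ccccc3)nn2)cc1`: > 100000 nM
compound 2 `O=C1O[C@H]([C@@H](O)Cn2cc(C3CC3)nn2)C(OCc2ccccc2)=C1OCc1ccccc1`: 24300 nM

Compound 1 stands at the limit of > 100000 nM in this assay, at which 1 of the 2 values shown sits; its value of > 100000 nM is a limit of the assay, not a number. Compound 2, in this assay, gives a number, 24300 nM. Within the data shown here, no pair of measured compounds differs in one place, so no measured step is available for this series.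

Compound 3 `O=C1O/C(=C\Cn2cc(-c3cccc(O)c3)nn2)C(OCc2ccccc2)=C1OCc1ccccc1` differs from compound 1 by 3-hydroxyphenyl in place of 4-methylphenyl on an aromatic carbon. Among the measured compounds shown here, no measured step of this kind exists, so the size of the change cannot be read from data; the expectation is for no step beyond the scatter, and compound 3 is expected to remain at or near the limit where compound 1 stands.

The step from compound 1 to compound 3 is estimated as a number no higher from compound 1 to compound 3 (the limit leaves the size open). For compound 3 in this assay the estimate is 100000 nM, with a range from 30000 nM to 300000 nM.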

Compound 3, half-maximal inhibitory concentration: 42600 nM
Estimate against measurement, compound 3: 2.3-fold (0.37 log units) above; measured number inside the range.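

In this assay, among these compounds, 3-hydroxyphenyl in place of 4-methylphenyl on an aromatic carbon of the five-membered aromatic ring with 3 nitrogen gives an at least 2.3-fold lower number from compound 1 to compound 3 (0.37 log units; beyond the scatter) and shows that the read-out responds to the group at this position, which the earlier compounds could not show. Compound 1 gives > 100000 nM as a limit of the assay and not a number. The full size of the step stays open because one end of it is that limit: the limit of > 100000 nM in this assay, at which 1 of the 3 values shown sits.

The step exchanges the 4-methyl group for a 3-hydroxyl group in one move, so the share of the hydroxyl group and the share of its place on the phenyl ring cannot be separated. As far as these compounds go, how 3-methylphenyl, 4-hydroxyphenyl, 3-aminophenyl or 3-carboxyphenyl would read at this position remains open.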